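A few compounds are considered here, and "the series" means these few. Any claim that something is new, unique, unknown or untested is made for them only; others in the source may bear on it.

Three amides sharing one core have been tested in a functional assay on HCT-116 cells (Homo sapiens) for antiproliferative activity, read by MTT assay, with a stated time of 48 h; on this read-out lower numbers stand for stronger inhibition and higher numbers for weaker inhibition. Compound 1 `Cc1ccccc1C(=O)Nc1cccc(/C=C/C(=O)c2nc3ccccc3[nH]2)c1` gives 1870 nM, compound 2 `O=C(Nc1cccc(/C=C/C(=O)c2nc3ccccc3[nH]2)c1)c1cccc(C(F)(F)F)c1` gives 3360 nM, and compound 3 `COc1cccc(C(=O)Nc2cccc(/C=C/C(=O)c3nc4ccccc4[nH]3)c2)c1` gives 3680 nM. The three numbers sit close together: there is a 1.8-fold higher number from compound 1 to compound 2 (0.25 log units; within the scatter), a 2.0-fold higher number from compound 1 to compound 3 (0.29 log units; within the scatter) and a 1.1-fold higher number from compound 2 to compound 3 (0.04 log units; within the scatter), so none of the three can be told apart from the others in this assay.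

Compound 4 `Cc1cc(C)cc(C(=O)Nc2cccc(/C=C/C(=O)c3nc4ccccc4[nH]3)c2)c1` differs from compound 3 by a single change, (3,5-dimethylphenyl in place of 3-methoxyphenyl on a carbonyl carbon). Two of the measured steps also swap the aromatic group on that carbonyl carbon: a 2.0-fold higher number from compound 1 to compound 3 (0.29 log units; within the scatter) and a 1.1-fold higher number from compound 2 to compound 3 (0.04 log units; within the scatter). Both stayed within the scatter, so exchanging one substituent pattern on this ring for another has so far not moved the number in either direction. On that basis no step beyond the scatter is expected for compound 4 in this assay. Compound 4 is therefore estimated at 3000 nM, with a likely range from 1400 nM to 6500 nM. This estimate corresponds to an expected step of a 1.2-fold lower number from compound 3 to compound 4 (0.09 log units; within the scatter).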

Compound 4, half-maximal inhibitory concentration: 1550 nM
For compound 4 the middle estimate is 1.9-fold (0.29 log units) above the measured one, within the range that was stated.
By their numbers in this assay, from the lowest: compounds 4, 1, 2 and 3 (each within the scatter of the next, the first and the last beyond it).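

In this assay, the aromatic group on the carbonyl carbon now gives its first steps beyond the scatter, both modest: 3,5-dimethylphenyl in place of 3-methoxyphenyl gives a 2.4-fold lower number from compound 3 to compound 4 (0.38 log units; beyond the scatter), and in place of 3-(trifluoromethyl)phenyl it gives a 2.2-fold lower number from compound 2 to compound 4 (0.34 log units; beyond the scatter). Replacing 2-methylphenyl with the same group gives only a 1.2-fold lower number from compound 1 to compound 4 (0.08 log units; within the scatter), so these two methyl-bearing rings cannot be told apart, yet compound 1 also stays within the scatter of compounds 2 and 3, which keeps the methyl-bearing rings from forming a clean group. No measurement available here explains why this change moves the number.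

All four compounds carry a substituted phenyl ring on this carbonyl carbon. As far as these compounds go, how an amine, a carboxylic acid or a longer chain on that ring would read remains open.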